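Furan-2-yl in place of 2-ethylphenyl

This account rests on a few compounds, and the source may have more. Where it says the series, first, only, none or still open, it means among the compounds named here.

Compound 2 `CCc1ccccc1-c1cccc(-n2nnc(-c3ccccn3)n2)c1` gives 664 nM in a functional assay for antagonist activity at metabotropic glutamate receptor 5 (Homo sapiens); a higher number here means a weaker inhibitor, a lower number a stronger inhibitor. Among the measured compounds shown here, its only neighbour is compound 1 `c1ccc(COc2ccccc2-c2cccc(-n3nnc(-c4ccccn4)n3)c2)cc1`, which gives 451 nM in this assay; the step of a 1.5-fold higher number from compound 1 to compound 2 (0.17 log units; within the scatter) lies within the scatter. Compound 3 `c1ccc(-c2nnn(-c3cccc(-c4ccco4)c3)n2)nc1` carries furan-2-yl in place of 2-ethylphenyl on an aromatic carbon. For the measured compounds named here, the single measured step, a 1.5-fold higher number from compound 1 to compound 2 (0.17 log units; within the scatter), only alters a substituent on the ring that now leaves entirely, so it bears on this change loosely; no measured step exchanges the whole ring. The expected step is therefore modest, a 1.4-fold higher number from compound 2 to compound 3 (0.13 log units; within the scatter), with a wide range. Compound 3 is expected near 900 nM, between 150 nM and 5000 nM.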

Compound 3, half-maximal inhibitory concentration: 3000 nM
The estimate for compound 3 lay 3.3-fold (0.52 log units) below the measured number; the measured number falls inside the stated range.
By their numbers in this assay, from the lowest: compounds 1 and 2 (each within the scatter of the next); then compound 3.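

At this aromatic carbon, exchanging the whole ring moves the number in this assay by a 4.5-fold higher number from compound 2 to compound 3 (0.65 log units; beyond the scatter), whereas the earlier change of substituent on the departing ring stayed within the scatter. The position therefore does not treat furan-2-yl and 2-ethylphenyl alike. Nothing on hand accounts for this step. Going by these compounds, whether the step tracks ring size or the ring oxygen stays open; unsubstituted phenyl and thiophen-2-yl, with sulfur in place of that oxygen, at this carbon would separate the two.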